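The source may report more compounds than this note shows. Statements on the series, on what has been measured and on what is new or still open speak of the compounds shown alone.

In a functional assay on HT-29 cells (Homo sapiens) for cytotoxicity, read by MTT assay, with a stated time of 72 h (a higher number here means a weaker inhibitor, a lower number a stronger inhibitor), compound 3 `COc1cc2c(Oc3ccc(NC(=O)c4nccc(-c5ccc(C)cc5)n4)cc3F)ccnc2cc1OCCCN1CCCCC1` gives 620 nM, the highest of the three numbers at hand. Its nearest neighbour is compound 2 `COc1cc2c(Oc3ccc(NC(=O)c4nccc(-c5ccccc5)n4)cc3F)ccnc2cc1OCCCN1CCCCC1`, which in this assay gives 260 nM, and the furthest is compound 1 `COc1cc2c(Oc3ccc(NC(=O)c4cc(-c5ccccc5F)ccn4)cc3F)ccnc2cc1OCCCN1CCN(C)CC1`, which gives 220 nM. Going by the values given here, the only measured step that touches the same aromatic carbon is a 2.4-fold higher number from compound 2 to compound 3 (0.38 log units; beyond the scatter), a methyl in place of hydrogen on the six-membered aromatic ring of carbon only. Compound 4 `COc1cc2c(Oc3ccc(NC(=O)c4nccc(-c5ccc(F)cc5)n4)cc3F)ccnc2cc1OCCCN1CCCCC1` changes that same carbon again: fluoro in place of methyl on an aromatic carbon. Among the compounds with values here, no measured pair sets fluoro against methyl directly, so the expectation rests on the hydrogen-bearing compound 2 and the methyl-bearing compound 3 alone. A fluoro, counted as one heavy atom like the methyl it replaces, is expected to fall between those two points rather than beyond either of them. On that basis the step is expected to be a 1.6-fold lower number from compound 3 to compound 4 (0.21 log units; within the scatter), a modest gain. Compound 4 is therefore estimated at 380 nM, within a range of 180 nM to 800 nM.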

Compound 4, half-maximal inhibitory concentration: 120 nM
Beside the measured number, compound 4's estimate is 3.2-fold (0.50 log units) above it, and the stated range ends above it.
By their numbers in this assay, from the lowest: compounds 4, 1 and 2 (each within the scatter of the next, the first and the last beyond it); then compound 3.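

In this assay, the change from 4-methylphenyl to 4-fluorophenyl gives a 5.2-fold lower number from compound 3 to compound 4 (0.71 log units; beyond the scatter), and fluoro in place of hydrogen at the same carbon gives a 2.2-fold lower number from compound 2 to compound 4 (0.34 log units; beyond the scatter). The earlier step at this carbon, para to a large group, was a loss, a 2.4-fold higher number from compound 2 to compound 3 (0.38 log units; beyond the scatter), so it could not show that a single heavy atom here can also bring a gain; methyl and fluoro in fact fall on opposite sides of hydrogen. No measurement at hand gives a reason for this split.

On these data alone, whether the gain stays with fluoro or extends to chloro or trifluoromethyl at this carbon remains open. So does whether methoxy or an amine here would follow fluoro or methyl.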